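The compounds below may be only part of what the source reports. "The series", "measured", "known", "first", "only" and "open" are said of these compounds alone.

Of the compounds shown here, three have been measured in a functional assay on NCI-H1299 cells (Homo sapiens) for antiproliferative activity, read by XTT assay, with a stated time of 72 h; a higher number here means a weaker inhibitor, a lower number a stronger inhibitor. Compound 1 `COc1ccc(-c2cc3ccccc3nc2C=O)cc1` gives > 10000 nM, which is a limit of the assay and not a number. Compound 2 `COc1ccc(-c2cc3ccccc3nc2/C=C/C(=O)c2ccc(F)cc2)cc1` gives 820 nM, and compound 3 `COc1ccc(C(=O)/C=C/c2nc3ccccc3cc2-c2ccc(OC)cc2)cc1` gives 6420 nM. Compound 3 therefore holds the higher of the two actual numbers, and so is the weaker inhibitor of that pair, with a 7.8-fold higher number from compound 2 to compound 3 (0.89 log units; beyond the scatter).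

The next structure, compound 4 `COc1ccc(-c2cc3ccccc3nc2/C=C/C(=O)c2ccc(N)cc2)cc1`, has amino in place of methoxy on an aromatic carbon, on a six-membered aromatic ring of carbon only, para to a large group (amino in place of methoxy on an aromatic carbon). In other words, 4-methoxyphenyl becomes 4-aminophenyl. Within the data shown here, only one measured step bears on this change, a 7.8-fold higher number from compound 2 to compound 3 (0.89 log units; beyond the scatter), where methoxy replaced fluoro at the same place. That single step shows that this assay responds to a change at this carbon, but amino itself has not been tested there. A move towards a lower number is therefore expected, probably smaller than the measured step, and the direction remains uncertain. The expected change is a 3.2-fold lower number from compound 3 to compound 4 (0.51 log units; beyond the scatter). For compound 4 the estimated value is 2000 nM, with an expected range from 400 nM to 9000 nM.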

Compound 4, half-maximal inhibitory concentration: 6510 nM
Compound 4: the middle estimate sits 3.3-fold (0.51 log units) below what was measured; the measured number falls inside the stated range.
By their numbers in this assay, from the lowest: compound 2; then compounds 3 and 4 (each within the scatter of the next). At a limit, above all of these: compound 1.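

In this assay, among these compounds, the new result separates two questions that the single earlier step could not: a 1.0-fold higher number from compound 3 to compound 4 (0.01 log units; within the scatter) shows that amino and methoxy on this aromatic carbon cannot be told apart, even though the two groups differ by one hydrogen-bond donor and in heavy-atom count. The earlier step, a 7.8-fold higher number from compound 2 to compound 3 (0.89 log units; beyond the scatter), might have been a property of methoxy alone, but a 7.9-fold higher number from compound 2 to compound 4 (0.90 log units; beyond the scatter) shows that a second replacement of fluoro gives a shift of similar size, so compound 2 now has the lowest number of the three compounds that differ at this place. The results shown give no measured reason for this behaviour, and nothing offered alongside them bears on the change from methoxy to amino.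

As far as these compounds go, what remains open is whether the lower number belongs to fluoro specifically or would also appear with chloro, a trifluoromethyl group or plain hydrogen on this carbon. From the compounds shown here alone, it is also open whether a carboxylic acid or a dimethylamino group here would leave the number where amino and methoxy put it or would move it further.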